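Predicting Compound 4: Methyl in Place of Methoxy

The compounds below may be only part of what the source reports. "The series", "measured", "known", "first", "only" and "open" are said of these compounds alone.

Compound 1, `O=C1CC(c2c[nH]c3cc(F)ccc23)C(=O)N1`, in an assay on isolated protein for inhibition of Indoleamine 2,3-dioxygenase 1 (Homo sapiens), with a stated time of 15 min (on this read-out higher numbers stand for weaker inhibition and lower numbers for stronger inhibition), gives 3400 nM.
Compound 2, `O=C1CC(c2c[nH]c3cc(Cl)ccc23)C(=O)N1`, in this assay gives 2100 nM.
Compound 3, `COc1ccc2c(C3CC(=O)NC3=O)c[nH]c2c1`, in this assay gives > 50000 nM, which is a limit of the assay and not a number.

Among the three measured compounds, compound 3 stands apart: its result is only a limit, (the limit of > 50000 nM in this assay, at which 1 of the 3 values shown sits), so its true value is unknown beyond that bound. The two steps leading to it, an at least 14-fold higher number from compound 1 to compound 3 (1.16 log units; beyond the scatter) and an at least 23-fold higher number from compound 2 to compound 3 (1.37 log units; beyond the scatter), are both large, whereas a 1.6-fold lower number from compound 1 to compound 2 (0.21 log units; within the scatter) stays within the scatter. Compound 4, `Cc1ccc2c(C3CC(=O)NC3=O)c[nH]c2c1`, differs from compound 3 by methyl in place of methoxy on an aromatic carbon. Within the data shown here, no measured step involves methyl at this position, so the two large steps to compound 3 are the only guide, and they show that fluoro and chloro give numbers while methoxy gives none. Compound 4 is therefore expected to give 15000 nM, with a range from 4000 nM to 60000 nM. This estimate implies an at least 3.3-fold lower number from compound 3 to compound 4 (0.52 log units; beyond the scatter), though a limit is again possible.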

Compound 4, half-maximal inhibitory concentration: 54000 nM
Compound 4: the middle estimate sits 3.6-fold (0.56 log units) below what was measured; the range from low to high includes it.
By their numbers in this assay, from the lowest: compounds 2 and 1 (each within the scatter of the next); then compound 4.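

Swapping fluoro or chloro for methyl at this position costs as much as the swap for methoxy did: in this assay there is a 26-fold higher number from compound 2 to compound 4 (1.41 log units; beyond the scatter), and there is a 16-fold higher number from compound 1 to compound 4 (1.20 log units; beyond the scatter). Weak inhibition here is therefore not confined to methoxy, since methyl carries no oxygen and no hydrogen-bond acceptor and still falls far behind both halogen compounds. Whether methyl is any better or worse than methoxy cannot be read, because compound 3 has only a limit of the assay and not a number: the limit of > 50000 nM in this assay, at which 1 of the 4 values shown sits.

The compounds shown leave open why fluoro and chloro are tolerated here while methyl and methoxy are not. They also leave open whether bromo, a nitrile or an amine at this position would match the halogen compounds or go beyond them.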